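Benzyl Substituent Swap on an Imidazole Ester Series

A few compounds are considered here, and "the series" means these few. Any claim that something is new, unique, unknown or untested is made for them only; others in the source may bear on it.

Measured compounds:
compound 1, `CCOC(=O)c1c(C)nc(-c2cccc(C#N)c2)n1OC(C)C`, 6740 nM
compound 2, `CCOC(=O)c1c(C)nc(-c2cccc(C#N)c2)n1OCc1cccc(Cl)c1`, 19400 nM

Both compounds were tested in a functional assay on a cell-free system (plasma, Oryctolagus cuniculus) for inhibition, with stated times of 5 min, 1 min and 6 min; a higher number here means a weaker inhibitor, a lower number a stronger inhibitor. Compound 2 stands at the higher of the two numbers; its nearest neighbour is compound 1, and the step of a 2.9-fold higher number from compound 1 to compound 2 (0.46 log units; beyond the scatter) lies beyond the scatter, so compound 2 is the weaker inhibitor of the pair. Among the measured compounds shown here, the only change measured so far is that of isopropyl to 3-chlorobenzyl on an oxygen on an aromatic ring.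

Compound 3, `CCOC(=O)c1c(C)nc(-c2cccc(C#N)c2)n1OCc1ccc(C#N)cc1`, differs from compound 2 by 4-cyanophenyl in place of 3-chlorophenyl on a saturated chain carbon bound to an oxygen on an aromatic ring. For the measured compounds named here, no measured step touches the substituent pattern of this benzyl ring: the single known step, a 2.9-fold higher number from compound 1 to compound 2 (0.46 log units; beyond the scatter), concerns the exchange of isopropyl for the whole 3-chlorobenzyl group and says nothing about trading one substituent on that ring for another. Going by the values given here, with no bearing step, the number for compound 3 in this assay is expected to stay close to that of compound 2, with no step beyond the scatter in either direction, so that a 1.1-fold lower number from compound 2 to compound 3 (0.03 log units; within the scatter) is the estimated change. Compound 3 is therefore estimated at 18000 nM, with a range from 6000 nM to 55000 nM.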

Compound 3, half-maximal inhibitory concentration: 4240 nM
Estimate against measurement, compound 3: 4.2-fold (0.63 log units) above, and the stated range ends above it.
By their numbers in this assay, from the lowest: compounds 3 and 1 (each within the scatter of the next); then compound 2.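

In this assay, the substituent on the benzyl ring turns out to matter at this position: 4-cyanophenyl in place of 3-chlorophenyl on a saturated chain carbon bound to an oxygen on an aromatic ring gives a 4.6-fold lower number from compound 2 to compound 3 (0.66 log units; beyond the scatter) and so reverses the loss seen earlier in a 2.9-fold higher number from compound 1 to compound 2 (0.46 log units; beyond the scatter). That loss therefore belongs to the 3-chlorobenzyl group and does not extend to both benzyl groups shown, since 4-cyanobenzyl in place of isopropyl gives only a 1.6-fold lower number from compound 1 to compound 3 (0.20 log units; within the scatter) and leaves compound 3 and compound 1 indistinguishable. Nothing at hand explains the difference between the two benzyl groups.

The step from compound 2 to compound 3 exchanges the chlorine for a nitrile and also moves the substituent, so the compounds shown cannot say which of the two changes carries the effect, a question that 4-chlorobenzyl or 3-cyanobenzyl on the same oxygen would address. Going by these compounds, it also remains open how the unsubstituted benzyl group, or a 4-carboxybenzyl group, would compare with isopropyl on this shared core.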